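Silyl ether flavone series: adding a ring hydroxy

This account rests on a few compounds, and the source may have more. Where it says the series, first, only, none or still open, it means among the compounds named here.

Measured so far in a functional assay on HT-29 cells (Homo sapiens) for cytotoxicity, read by MTT assay, with a stated time of 6 days; a lower number here means that less compound is needed, a higher number that more compound is needed for the effect:
- compound 1 `COC(=O)c1c(-c2ccc(OC)cc2)oc2ccccc2c1=O`: > 25 ug/mL (a limit)
- compound 2 `COc1cc(-c2cc(=O)c3ccc(O)cc3o2)cc(OC)c1OC`: > 25 ug/mL (a limit)
- compound 3 `COc1cc(-c2cc(=O)c3ccc(O)cc3o2)cc(OC)c1O[Si](C)(C)C(C)(C)C`: 1 ug/mL

For the measured compounds named here, compound 3 holds the only actual number. Compound 1 and compound 2 stand at the limit of > 25 ug/mL in this assay, at which 2 of the 3 values shown sit. Compound 3 therefore has no second number to be compared with, only its step from compound 2.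

Compound 4 `COc1cc(-c2cc(=O)c3ccc(O)c(O)c3o2)cc(OC)c1O[Si](C)(C)C(C)(C)C` is not yet measured. It differs from compound 3 in one place: hydroxy in place of hydrogen on an aromatic carbon. This is a hydroxy in place of hydrogen on an aromatic carbon, ortho to a hydroxy group.

Going by the values given here, the one measured step, an at least 25-fold lower number from compound 2 to compound 3 (1.39 log units; beyond the scatter), bears on compound 4 only in part. The group that entered in that step stays in compound 4, but the step says nothing about a new hydroxy on the ring. Among the compounds with values here, no measured pair covers that change, so the expectation in this assay is for no shift beyond the scatter and no firm direction, with a wide range.

The expected change is a 1.5-fold higher number from compound 3 to compound 4 (0.18 log units; within the scatter). In this assay, compound 4 is estimated at 1.5 ug/mL, with an expected range of 0.4 ug/mL to 6 ug/mL.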

Compound 4, concentration for half-maximal effect: 0.34 ug/mL
Compound 4: middle estimate off by 4.4-fold (0.64 log units), on the high side, outside the stated range (below it).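

In this assay, hydroxy in place of hydrogen on an aromatic carbon, ortho to a hydroxy group, gives a 2.9-fold lower number from compound 3 to compound 4 (0.47 log units; beyond the scatter), so this carbon of the core is a place where a single added group moves the number beyond the scatter, and in the direction of less compound needed. The earlier step, an at least 25-fold lower number from compound 2 to compound 3 (1.39 log units; beyond the scatter), was a change on an oxygen on an aromatic ring and showed nothing about this carbon; the new step shows that the silyl ether group is not the only place in the series where a change registers. The values shown give no reason for the new step.

Still open is whether the added hydroxy acts the same way on a compound without the silyl ether group, since the compounds shown read this change only with that group in place. Also open, from the compounds shown here alone, is whether the shift is specific to hydroxy or would also appear with another group on this carbon, such as an amine or a carboxylic acid.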